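A few compounds are considered here, and "the series" means these few. Any claim that something is new, unique, unknown or untested is made for them only; others in the source may bear on it.

Compound 1 `COc1ccc(/C=C(/Sc2ccc(C)cc2)C(=O)c2ccc(Cl)cc2)cc1O` is a micromolar-range starting point: in a functional assay on DU-145 cells (Homo sapiens) for inhibition, read by trypan blue exclusion, with a stated time of 96 h (a lower number here means a stronger inhibitor of growth, a higher number a weaker inhibitor of growth), compound 1 gives 1000 nM. Among the measured compounds shown here, its only measured neighbour, compound 2 `COc1ccc(/C=C(\C(=O)c2ccc(Cl)cc2)S(=O)(=O)c2ccc(C)cc2)cc1O`, gives 1000 nM in this assay, so the two stand level. Compound 3 `Cc1ccc(S/C(=C/c2c[nH]c3ccccc23)C(=O)c2ccc(Cl)cc2)cc1` keeps the rest of compound 1 and exchanges one group: 1H-indol-3-yl in place of 3-hydroxy-4-methoxyphenyl on a double-bonded chain carbon bound to a double-bonded chain carbon. Thus 1H-indol-3-yl stands in place of 3-hydroxy-4-methoxyphenyl on a double-bonded chain carbon bound to a double-bonded chain carbon.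

For the measured compounds named here, only one measured step is available, no change at the digits printed from compound 1 to compound 2 (within the scatter), and it lies within the scatter. That step alters the (4-methylphenyl)sulfanyl group rather than the group exchanged here, so it bears on this change only indirectly. Going by the values given here, no measured compound carries 1H-indol-3-yl, and the data give no direction for the exchange. The expectation therefore stays anchored on compound 1 at 1000 nM, with no shift beyond the scatter expected in this assay but with wide uncertainty. The expected size of the change is a 1.3-fold higher number from compound 1 to compound 3 (0.11 log units; within the scatter). For compound 3, the estimated value is 1300 nM, with an expected range from 300 nM to 6000 nM.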

Compound 3, concentration for 50% growth inhibition: 10000 nM
Compound 3: the middle estimate sits 7.7-fold (0.89 log units) below what was measured; the measured number lies above the stated range.
By their numbers in this assay, from the lowest: compounds 1 and 2 (each within the scatter of the next); then compound 3.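

In this assay, placing 1H-indol-3-yl in place of 3-hydroxy-4-methoxyphenyl on a double-bonded chain carbon bound to a double-bonded chain carbon gives a 10-fold higher number from compound 1 to compound 3 (1.00 log units; beyond the scatter) and so weakens growth inhibition. Among the compounds shown here, this position therefore responds to exchange, whereas the only earlier step, at the sulfur-bearing group, showed no change at the digits printed from compound 1 to compound 2 (within the scatter) in the same read-out. The leaving and entering groups match in heavy atoms and hydrogen-bond donors but differ in their rings and hydrogen-bond acceptors, and nothing available here explains the weaker result.

The compounds shown leave open which part of the exchange matters, as well as whether the same exchange would weaken growth inhibition when the (4-methylphenyl)sulfonyl group of compound 2 is present. A 4-methoxyphenyl group carrying an amine in place of the hydroxy, or a 1H-indol-3-yl group bearing a methoxy substituent, would test the question more narrowly than this single replacement of one whole group by another.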